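The compounds below may be only part of what the source reports. "The series", "measured", "known", "first", "only" and "open" are said of these compounds alone.

Among the measured compounds shown here, in an ADME assay on C8166 cells (Homo sapiens) for cytotoxicity, read by MTT assay (on this read-out higher numbers stand for lower toxicity in this test and lower numbers for higher toxicity in this test), compound 2 `Cc1cc(S(N)(=O)=O)ccc1NC(=O)COc1ccc(Cl)cc1Oc1c(C)cc2ccccc2c1Cl` gives 42600 nM, the highest of the two numbers measured so far. For the measured compounds named here, compound 1 `Cc1cc(S(N)(=O)=O)ccc1NC(=O)COc1ccc(Cl)cc1Oc1ccc2cc(Br)ccc2c1` gives 31300 nM in this assay, and the single measured step, a 1.4-fold higher number from compound 1 to compound 2 (0.13 log units; within the scatter), stays within the scatter. Compound 3 `Cc1cc(S(N)(=O)=O)ccc1NC(=O)COc1ccc(Cl)cc1Oc1cc2ccccc2cc1C` differs from compound 2 by hydrogen in place of chloro on an aromatic carbon. Going by the values given here, no measured step bears directly on loss of this chloro; the one step known, a 1.4-fold higher number from compound 1 to compound 2 (0.13 log units; within the scatter), changed the same naphthyl region without moving the number beyond the scatter, so no step beyond the scatter is expected in this assay. The step expected is a 1.1-fold lower number from compound 2 to compound 3 (0.03 log units; within the scatter). Compound 3 is thus estimated at 40000 nM in this assay, within 20000 nM to 80000 nM.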

Compound 3, half-maximal cytotoxic concentration: 76700 nM
The estimate for compound 3 lay 1.9-fold (0.28 log units) below the measured number; low and high end bracket the measured number.
By their numbers in this assay, from the lowest: compounds 1, 2 and 3 (each within the scatter of the next, the first and the last beyond it).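

In this assay hydrogen in place of chloro on this aromatic carbon gives a 1.8-fold higher number from compound 2 to compound 3 (0.26 log units; within the scatter), so the chloro is not needed to keep the number at this level. Among the compounds shown here, the 3-methylnaphthalen-2-yl group in place of 6-bromonaphthalen-2-yl gives a 2.5-fold higher number from compound 1 to compound 3 (0.39 log units; beyond the scatter), the first modest step beyond the scatter. Nothing available explains either step.

As far as these compounds go, whether an amine or a methoxy group on this carbon would stay within the scatter of chloro and hydrogen remains open. Also open, from the compounds shown here alone, is how much of the step from the bromo compound belongs to the bromo group and how much to the methyl group.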